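Adding a bromo group to compound 1's aromatic ring

The compounds below may be only part of what the source reports. "The series", "measured", "known", "first", "only" and "open" are said of these compounds alone.

Within the data shown here, compound 1 `C/N=C1\NC(=O)/C(=C/c2c[nH]c3ccccc23)N1` is the stronger of the two compounds measured so far: in an assay on isolated protein for displacement of a labelled ligand from 5-hydroxytryptamine receptor 4 (Homo sapiens) (on this read-out higher numbers stand for weaker inhibition and lower numbers for stronger inhibition), compound 1 gives 928 nM. Compound 2 `CSC1=NC(=O)/C(=C/c2c[nH]c3ccc(Br)cc23)N1` has a different core and gives 3800 nM. Compound 3 `C/N=C1\NC(=O)/C(=C/c2c[nH]c3c(Br)cccc23)N1` differs from compound 1 by one change, (bromo in place of hydrogen on an aromatic carbon). Among the measured compounds shown here, no measured pair shows what this change does here, so the step from compound 1 to compound 3 is expected to be small, likely within the scatter or a little toward weaker binding, as a 1.4-fold higher number from compound 1 to compound 3 (0.15 log units; within the scatter). Compound 3 is therefore expected to give 1300 nM, within a range from 400 nM to 4500 nM.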

Compound 3, inhibition constant: 603 nM
For compound 3 the middle estimate is 2.2-fold (0.33 log units) above the measured one; low and high end bracket the measured number.
By their numbers in this assay, from the lowest: compounds 3 and 1 (each within the scatter of the next); then compound 2.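

In this assay bromo in place of hydrogen on an aromatic carbon, ortho to a fused ring and meta to a fused ring, gives a 1.5-fold lower number from compound 1 to compound 3 (0.19 log units; within the scatter) and so leaves compound 3 indistinguishable from compound 1. Among these compounds, this position therefore accepts a bromine atom, and this is the first step here that isolates one change. Nothing measured here explains this result. Still open, from the compounds shown here alone, is whether a methoxy group, an amine or a carboxylic acid would be accepted at this position. Whether bromo on another carbon of this ring would behave alike is also unknown.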